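This account rests on a few compounds, and the source may have more. Where it says the series, first, only, none or still open, it means among the compounds named here.

Three compounds have been tested so far in an ADME assay on BAEC cells (Bos taurus) for cytotoxicity, read by MTT assay, with a stated time of 2 days (a lower number here means a stronger inhibitor, a higher number a weaker inhibitor), and give these results:

compound 1 `COC(=O)COc1c(C=O)cc(Br)c(OC)c1Br` gives 151000 nM
compound 2 `COc1c(Br)cc(/C=C2\N=C(c3ccccc3)OC2=O)c(OCc2ccccc2)c1Br` gives 921000 nM
compound 3 `COc1c(Br)cc(/C=C2\N=C(c3ccccc3)OC2=O)c(OC(=O)c2ccccc2)c1Br` gives > 18000 nM as a limit, not a number

Compound 3 has no exact place on this scale, since > 18000 nM is only a limit of the assay the limit of > 18000 nM in this assay, at which 1 of the 3 values shown sits, and nothing more is known of it.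

Compound 4 `COc1c(Br)cc(/C=C2\N=C(c3ccccc3)OC2=O)c(O)c1Br` differs from compound 3 by a single change hydrogen in place of benzoyl on an oxygen on an aromatic ring with hydrogen in place of benzoyl on an oxygen on an aromatic ring, so benzoyloxy becomes hydroxy. Among the compounds with values here, the one measured step at this oxygen is a step that the limit leaves unreadable from compound 2 to compound 3 with benzoyl in place of benzyl, and it offers no size to carry over. The remaining guide is the pair of real numbers, with compound 1 at 151000 nM and compound 2 at 921000 nM in the same assay. The expected step is a step that the limit leaves unreadable from compound 3 to compound 4 in this assay and remains a rough estimate with no firm direction. For compound 4 the estimated value is 100000 nM with an expected range from 25000 nM to 500000 nM in this set.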

Compound 4, half-maximal inhibitory concentration: > 22000 nM
Compound 4: no number, only a limit (the forecaster's own chance of this, stated with the estimate: 25%); the middle value lies beyond the limit too.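

No new step can be read for compound 4 against compound 2 or compound 3: compound 4, like compound 3, has only a limit, not a number. As far as these compounds go, what stays open is where compound 3 and compound 4 truly lie in this assay, and whether benzyl, benzoyl or hydrogen on that oxygen changes the result at all.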